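Cytotoxicity Limits Along an Aryl Exchange in Compound 4

The compounds below may be only part of what the source reports. "The series", "measured", "known", "first", "only" and "open" are said of these compounds alone.

Compound 3 `COc1ccc(F)c(-c2ccc(C(=O)N(Cc3cccc(OCCCCCC(=O)O)c3)C(C)C)cc2)c1` was tested in an ADME assay on HepG2 cells (Homo sapiens) for cytotoxicity, read by CellTiter-Glo and resazurin assay, with a stated time of 72 h (a lower number here means that less compound is needed, a higher number that more compound is needed for the effect), and gives > 26000 nM, which is a limit of the assay and not a number. The two compounds beside it sit in the same position. Compound 1 `CC(C)N(Cc1cccc(OCCCCCC(=O)O)c1)C(=O)c1ccccc1` gives > 26000 nM in this assay, again a limit. Compound 2 `CC(C)N(Cc1cccc(OCCCCCC(=O)O)c1)C(=O)c1ccc(-c2cccc(Oc3ccccc3)c2)cc1` gives > 18700 nM, also a limit. For the measured compounds named here, the only single-point step among them, a step that the two limits leave unreadable from compound 1 to compound 3, therefore cannot be read, as both ends are limits; the evidence consists of the limit of > 18700 nM in this assay, at which 1 of the 3 values shown sits, and (the limit of > 26000 nM in this assay, at which 2 of the 3 values shown sit), and no value in this assay stands as a number.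

Compound 4 `CC(C)N(Cc1cccc(OCCCCCC(=O)O)c1)C(=O)c1ccc(-c2cccc(C(F)(F)F)c2)cc1` differs from compound 3 by 3-(trifluoromethyl)phenyl in place of 2-fluoro-5-methoxyphenyl on an aromatic carbon. Going by the values given here, no measured step bears on this exchange with a readable size, since every measured value in this assay is a limit. The expectation for compound 4 rests on the observation that compounds 1, 2 and 3 all sit at limits, so compound 4 is expected to stay at or near the limit as well, with a step that the limit leaves unreadable from compound 3 to compound 4 being no step beyond the scatter. Compound 4 is thus estimated at 30000 nM in this assay, within a range from 10000 nM to 100000 nM.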

Compound 4, half-maximal effective concentration: > 26000 nM
Compound 4 gave a limit, no number; the forecaster's own chance of this, stated with the estimate: 85%; the middle value does not contradict the limit.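

Compound 1, compound 2, compound 3 and compound 4 all stand at limits in this assay, so the steps from compound 1, compound 2 and compound 3 to compound 4 cannot be read. The compounds shown leave open at what concentration each would reach the half-maximal effect, and whether these aryl exchanges change it at all.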